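From 3-hydroxybenzyl to 4-methoxybenzyl in the series

The compounds below may be only part of what the source reports. "The series", "measured", "known", "first", "only" and "open" are said of these compounds alone.

Of the compounds shown here, two sharing one core have numbers so far in a functional assay on HCT-116 cells (Homo sapiens) for inhibition, read by MTT assay, with a stated time of 48 h; a lower number here means a stronger inhibitor, a higher number a weaker inhibitor. Compound 1 (`C/C=C/C(=O)N(Cc1ccc(OC)c(OC)c1)c1cc(OC)c(OC)c(OC)c1`) gives 32800 nM. Compound 2 (`C/C=C/C(=O)N(Cc1cccc(O)c1)c1cc(OC)c(OC)c(OC)c1`) gives 6700 nM, the lower of the two numbers, and its gap to compound 1 lies beyond the scatter. For the measured compounds named here, no pair of measured compounds differs in one place only, so no single change has yet been sized directly.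

The next entry is compound 3 (`C/C=C/C(=O)N(Cc1ccc(OC)cc1)c1cc(OC)c(OC)c(OC)c1`), which has 4-methoxyphenyl in place of 3-hydroxyphenyl on a saturated chain carbon bound to an amide-type nitrogen. Going by the values given here, the only other measured compound without the 3-hydroxyphenyl group is compound 1 at 32800 nM, and this single comparison is the whole basis for expecting a higher number in this assay. The expected change is a 2.7-fold higher number from compound 2 to compound 3 (0.43 log units; beyond the scatter), a weakening that probably lies beyond the scatter, though a result close to compound 2 cannot be excluded. For compound 3 the estimated value is 18000 nM, with an expected range of 6500 nM to 45000 nM.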

Compound 3, half-maximal inhibitory concentration: 500 nM
Compound 3: the middle estimate sits 36-fold (1.56 log units) above what was measured; the whole stated range lies above it.
By their numbers in this assay, from the lowest: compound 3; then compound 2; then compound 1.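

On the saturated chain carbon bound to an amide-type nitrogen, the choice of aryl group has a large effect on the number in this assay: 4-methoxyphenyl in place of 3-hydroxyphenyl gives a 13-fold lower number from compound 2 to compound 3 (1.13 log units; beyond the scatter) on the shared core. The substitution pattern on this ring also matters, since hydrogen in place of methoxy on an aromatic carbon gives a 66-fold lower number from compound 1 to compound 3 (1.82 log units; beyond the scatter) and compound 3 therefore stands well ahead of the compound that carries the additional methoxy group. No measurement at hand accounts for either step.

The change from compound 2 to compound 3 alters both the substituent and its place on the ring, so the compounds shown cannot say which of the two carries the gain; 4-hydroxyphenyl and 3-methoxyphenyl would separate them. Also open, on these data alone, is whether a longer group such as 4-ethoxyphenyl, or an amine as in 4-aminophenyl, would keep the low number of compound 3 at this position.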